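Ring-nitrogen aryl swap in a thiazolidinone amide series

The compounds below may be only part of what the source reports. "The series", "measured", "known", "first", "only" and "open" are said of these compounds alone.

Measured so far:
compound 1 `O=C(NCCCCc1ccccc1)c1cccc(C2SCC(=O)N2c2cccc(-c3c[nH]nn3)c2)c1` gives 110 nM
compound 2 `COc1ccccc1N1C(=O)CSC1c1cccc(C(=O)NCCCCc2ccc(Cl)cc2)c1` gives 78.6 nM
compound 3 `COc1ccc(F)cc1N1C(=O)CSC1c1cccc(C(=O)NCCCCn2cccn2)c1` gives 97.3 nM

All three values come from a functional assay on HOS-TE85 cells (Homo sapiens) for inhibition, read by CCK-8 assay, with a stated time of 72 h; a lower number here means a stronger inhibitor, a higher number a weaker inhibitor. Compound 3 sits second highest of the three numbers; its gap to compound 1 and its gap to compound 2 both lie within the usual scatter, so no order among the three is claimed.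

Compound 4 `O=C(NCCCCn1cccn1)c1cccc(C2SCC(=O)N2c2ccccn2)c1` has not yet been measured. It differs from compound 3 in one place: pyridin-2-yl in place of 5-fluoro-2-methoxyphenyl on an amide-type nitrogen in a ring. For the measured compounds named here, no measured pair isolates a change of this kind on the amide-type nitrogen in a ring, so the size of the step is not anchored by data. The expectation is a small shift, if any, toward a weaker inhibitor in this assay, estimated as a 1.3-fold higher number from compound 3 to compound 4 (0.13 log units; within the scatter). Compound 4 is estimated at 130 nM, with a range from 60 nM to 300 nM.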

Compound 4, half-maximal inhibitory concentration in the HOS-TE85 assay: 60.3 nM
The estimate for compound 4 lay 2.2-fold (0.33 log units) above the measured number, and the stated range covers the measured number.
By their numbers in the HOS-TE85 assay, from the lowest: compounds 4, 2, 3 and 1 (each within the scatter of the next).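

For the compounds shown here, in the HOS-TE85 assay the swap of 5-fluoro-2-methoxyphenyl for pyridin-2-yl gives a 1.6-fold lower number from compound 3 to compound 4 (0.21 log units; within the scatter) and is the first measured change on this amide-type nitrogen in a ring, which tolerates the loss of both methoxy and fluoro groups without a step beyond the scatter. In a physicochemical assay for solubility, read by turbidimetry, measured as kinetic solubility, at pH 7.4 (a lower number here means a less soluble compound, a higher number a more soluble compound), compound 3 gives 50000 nM and compound 4 gives 50000 nM with no change at the digits printed. No evidence on hand accounts for either result.

Open, going by these compounds, is how a piperidine group or a carboxylic acid would read at this nitrogen. Also open, on these data alone, is whether the step carries over to the amide side chains of compound 1 and compound 2.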